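Sulfonyl variation on the ring nitrogen

The compounds below may be only part of what the source reports. "The series", "measured", "known", "first", "only" and "open" are said of these compounds alone.

Compound 3 `COc1ccc(-c2cc(=O)c3c(OC)cc(OC)cc3n2S(=O)(=O)c2cccc(Br)c2)cc1` carries a (3-bromophenyl)sulfonyl group on the aromatic nitrogen of the shared core. In a functional assay on KOPN-8 cells (Homo sapiens) for antiproliferative activity, with a stated time of 72 h (on this read-out lower numbers stand for an effect already at smaller amounts and higher numbers for an effect only at larger amounts of compound), compound 3 reaches only a limit, > 58600 nM, so no number is known for it. Compound 1 `C=CCNC(=O)n1c(-c2ccc(OC)cc2)cc(=O)c2c(OC)cc(OC)cc21`, with an allylcarbamoyl group on the same nitrogen, gives 12000 nM in this assay; the step of an at least 4.8-fold higher number from compound 1 to compound 3 (0.68 log units; beyond the scatter) shows the sulfonyl variant to be weaker. Compound 2 `COc1ccc(-c2cc(=O)c3c(OC)cc(OC)cc3n2S(=O)(=O)c2cc(F)c(F)c(F)c2)cc1`, bearing a (3,4,5-trifluorophenyl)sulfonyl group, also returns only a limit in this assay, > 65500 nM. The step that the two limits leave unreadable from compound 2 to compound 3 cannot be read, since both ends sit at limits (the limit of > 58600 nM in this assay, at which 1 of the 3 values shown sits, (the limit of > 65500 nM in this assay, at which 1 of the 3 values shown sits)). Compound 4 `COc1ccc(-c2cc(=O)c3c(OC)cc(OC)cc3n2S(=O)(=O)Cc2ccccc2)cc1` differs from compound 3 by benzyl in place of 3-bromophenyl on a sulfonyl sulfur. For the measured compounds named here, both sulfonyl compounds measured so far lie at limits, and nothing shows that a benzyl group lifts a sulfonyl variant into the measurable range. The expectation for compound 4 is therefore a number near or beyond the limit, a step that the limit leaves unreadable from compound 3 to compound 4 without readable direction. Compound 4 is estimated at 60000 nM, range 20000 nM to 200000 nM, most likely again reported as a limit.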

Compound 4, half-maximal effective concentration: > 34400 nM
Compound 4: no number, only a limit (the forecaster's own chance of this, stated with the estimate: 75%); the middle value is on the limit's open side.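

In this assay compound 4 also returns only a limit, > 34400 nM, so benzylsulfonyl on the aromatic nitrogen joins the two arylsulfonyl groups in giving no number. The step of an at least 2.8-fold higher number from compound 1 to compound 4 (0.45 log units; beyond the scatter) puts this third sulfonyl variant on the weaker side of the allylcarbamoyl compound, so moving from an aromatic ring directly on the sulfonyl sulfur to benzyl does not bring the series into the measurable range. The steps among compounds 2, 3 and 4 cannot be read, and no order among these three sulfonyl groups can be stated.

On these data alone, whether any sulfonyl group on this nitrogen gives a number in this assay remains open, for instance one carrying an amine or a carboxylic acid. Also open, as far as these compounds go, is how a longer chain in place of allyl on the carbamoyl group would read.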